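The source may report more compounds than this note shows. Statements on the series, on what has been measured and on what is new or still open speak of the compounds shown alone.

Compound 1 `Cc1ccc(NS(=O)(=O)c2cccc(CCCCCCNC(=O)/C=C/c3cccnc3)c2)cc1`: 34.4 nM
Compound 2 `O=C(/C=C/c1cccnc1)NCCCCCCc1cccc(S(=O)(=O)Nc2ccc(F)cc2)c1`: 10.6 nM

In a functional assay on DU-145 cells (Homo sapiens) for inhibition, read by CCK-8 assay, with a stated time of 72 h (a lower number here means a stronger inhibitor, a higher number a weaker inhibitor), compound 2 holds the lower of these two numbers. Compound 3 `O=C(/C=C/c1cccnc1)NCCCCCCc1cccc(S(=O)(=O)Nc2ccc(Oc3ccccc3)cc2)c1` carries phenoxy in place of fluoro on an aromatic carbon, para to a large group (phenoxy in place of fluoro on an aromatic carbon). Among the measured compounds shown here, only one measured step bears on this change: the modest 3.2-fold lower number from compound 1 to compound 2 (0.51 log units; beyond the scatter), with fluoro in place of methyl on that carbon. For the measured compounds named here, no phenoxy compound has been measured, so the direction is uncertain, but a modest step toward a higher number is expected in this assay, estimated as a 1.9-fold higher number from compound 2 to compound 3 (0.28 log units; within the scatter). Compound 3 is expected at 20 nM, with an estimated range of 5 nM to 80 nM.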

Compound 3, half-maximal inhibitory concentration: 50.9 nM
Compound 3: middle estimate off by 2.5-fold (0.41 log units), on the low side; measured number inside the range.
By their numbers in this assay, from the lowest: compound 2; then compounds 1 and 3 (each within the scatter of the next).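

In this assay, the first group carrying its own aromatic ring at this carbon gives up the gain seen with fluoro, with a 4.8-fold higher number from compound 2 to compound 3 (0.68 log units; beyond the scatter). Set against methyl, the same phenoxy group gives a 1.5-fold higher number from compound 1 to compound 3 (0.17 log units; within the scatter), so compound 1 and compound 3 stay together and only fluoro stands apart among these three groups. Nothing available on these compounds accounts for this difference. Going by these compounds, what remains open is whether chloro, methoxy or an amine at this carbon would fall with fluoro or with methyl and phenoxy. Also open, on these data alone, is whether a benzyloxy group would give a number close to that of phenoxy.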